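Swapping Methyl for Chloro on a Urea Tail

A few compounds are considered here, and "the series" means these few. Any claim that something is new, unique, unknown or untested is made for them only; others in the source may bear on it.

Compound 1 `COc1ccc(NC(=O)Nc2cc(C)nc3ccccc23)cc1F` and compound 2 `Cc1cc(NC(=O)Nc2cc(F)ccc2F)c2ccccc2n1` join two aromatic parts through a urea link. In an ADME assay on BJ cells (Homo sapiens) for cytotoxicity, with a stated time of 72 h (a lower number here means that less compound is needed, a higher number that more compound is needed for the effect), compound 1 gives 26000 nM and compound 2 gives 7000 nM. Compound 3 `Cc1ccc(NC(=O)Nc2cc(C)nc3ccccc23)cc1` is a different case. In this assay compound 3 shows > 25000 nM, which is a limit of the assay rather than a measured number, and so sits at the limit of > 25000 nM in this assay, at which 1 of the 3 values shown sits. Compound 4 `Cc1cc(NC(=O)Nc2ccc(Cl)cc2)c2ccccc2n1` differs from compound 3 by chloro in place of methyl on an aromatic carbon. Among the measured compounds shown here, no measured pair in this set shows that same change, so its effect is untested here. For compound 4 the expected step in this assay is an at least 1.3-fold lower number from compound 3 to compound 4 (0.14 log units; that floor lies within the scatter), modest and toward a smaller number. Compound 4 is expected to give 18000 nM, within a range from 6000 nM to 50000 nM.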

Compound 4, half-maximal effective concentration: > 25000 nM
Compound 4 was reported as a limit (the forecaster's own chance of this, stated with the estimate: 40%); middle value at least 1.3-fold (0.14 log units) away from the limit.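

Compound 3 and compound 4 both stand at a limit in this assay, so no step can be read between them: the limit of > 25000 nM in this assay, at which 2 of the 4 values shown sit.

Whether chloro in place of methyl shifts the number in either direction stays open among the compounds shown.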